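Fluoro in Place of Chloro, Not Yet Measured

The source may report more compounds than this note shows. Statements on the series, on what has been measured and on what is new or still open speak of the compounds shown alone.

Among the measured compounds shown here, compound 2 `COc1ccc(Cl)cc1S(=O)(=O)Nc1cncc(C(N)=O)c1` gives 105 nM in an assay on isolated protein for inhibition of alkaline phosphatase, tissue-nonspecific isozyme (Homo sapiens) (on this read-out lower numbers stand for stronger inhibition and higher numbers for weaker inhibition), the only number among the three measured compounds. Compound 1 `CNC(=O)c1cncc(NS(=O)(=O)c2cc(Cl)ccc2OC)c1` reaches only the limit > 20000 nM. Compound 3 `CCNC(=O)c1cncc(NS(=O)(=O)c2cc(Cl)ccc2OC)c1` likewise sits at the limit > 20000 nM. Both limits fall at the limit of > 20000 nM in this assay, at which 2 of the 3 values shown sit. The measured steps of an at least 190-fold lower number from compound 1 to compound 2 (2.27 log units; beyond the scatter) and an at least 190-fold higher number from compound 2 to compound 3 (2.27 log units; beyond the scatter) concern the amide-type nitrogen, not the aromatic ring. Compound 4 `COc1ccc(F)cc1S(=O)(=O)Nc1cncc(C(N)=O)c1` differs from compound 2 by fluoro in place of chloro on an aromatic carbon. For the measured compounds named here, no measured step touches that position, so this change must be judged on its own. For compound 4 the expected step in this assay is a 2.1-fold higher number from compound 2 to compound 4 (0.32 log units; beyond the scatter), a modest weakening that may not exceed the scatter. Compound 4 is therefore estimated at 220 nM, between 60 nM and 900 nM.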

Compound 4, half-maximal inhibitory concentration: 109 nM
For compound 4 the middle estimate is 2.0-fold (0.30 log units) above the measured one; low and high end bracket the measured number.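

On the aromatic carbon para to the methoxy group, fluoro can replace chloro in this assay with no readable change: the step is a 1.0-fold higher number from compound 2 to compound 4 (0.02 log units; within the scatter). Among the compounds shown here, this is the only measured change on the aromatic ring, and it contrasts with the large steps seen on the amide-type nitrogen. Nothing shown explains why the two halogens give matching results. Going by these compounds, what a methyl, a nitrile or a hydrogen would do at this position stays open, since only two halogens appear there. Also open, on these data alone, is how a carboxylic acid would compare with the amide of compound 2.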